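The source may hold more compounds than are shown below. What is called first, only, known or untested is meant among the compounds shown, and "the series" means these compounds.

Compound 1 `COc1ccc(C2=NN(C3=NC(=O)/C(=C4\C(=O)Nc5ccccc54)S3)C(c3ccc(OC)cc3)C2)cc1` — 100000 nM
Compound 2 `COc1ccc(C2=NN(C3=NC(=O)/C(=C4\C(=O)Nc5ccc(Br)cc54)S3)C(c3ccc(OC)cc3)C2)cc1` — 280 nM
Compound 3 `COc1ccc(C2=NN(C3=NC(=O)/C(=C4\C(=O)Nc5ccc(Cl)cc54)S3)C(c3ccc(OC)cc3)C2)cc1` — 280 nM

Three compounds share one core and were tested in a functional assay on cells (Leukemia cell, Homo sapiens) for cytotoxicity, read by sulforhodamine B assay, with a stated time of 48 h; on this read-out higher numbers stand for weaker inhibition of growth and lower numbers for stronger inhibition of growth. Compound 1 gives 100000 nM in this assay. Adding a halogen to the aromatic ring changes the picture sharply: the step is a 360-fold lower number from compound 1 to compound 2 (2.55 log units; beyond the scatter) and a 360-fold lower number from compound 1 to compound 3 (2.55 log units; beyond the scatter). Compound 2 stands level with compound 3, the two together at the lowest numbers of the three, and the step between them is no change at the digits printed from compound 2 to compound 3 (within the scatter).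

Compound 4 `COc1ccc(C2CC(c3ccc4ccccc4c3)=NN2C2=NC(=O)/C(=C3\C(=O)Nc4ccc(Br)cc43)S2)cc1` has not yet been measured. It differs from compound 2 in one place: naphthalen-2-yl in place of 4-methoxyphenyl on a carbon with a double bond to nitrogen. Among the measured compounds shown here, none of the measured steps touches this part of the molecule; all three concern the halogen on the aromatic carbon, which compound 4 keeps as in compound 2. So the measured steps give no direct guidance on the size or direction of this change, and the expectation is worded cautiously.

Because compound 2 gives 280 nM in this assay and the halogen it carries is retained, compound 4 is expected to land near that figure, with the step of no change at the digits printed from compound 2 to compound 4 (within the scatter) expected to stay within the scatter. The estimate for compound 4 in this assay is 280 nM, with a range from 70 nM to 1200 nM.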

Compound 4, concentration for 50% growth inhibition: 130 nM
Compound 4: middle estimate off by 2.2-fold (0.33 log units), on the high side, and the stated range covers the measured number.
By their numbers in this assay, from the lowest: compound 4; then compounds 2 and 3 (each within the scatter of the next); then compound 1.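

In this assay, among the compounds shown here, the change from 4-methoxyphenyl to naphthalen-2-yl on the carbon with a double bond to nitrogen gives a 2.2-fold lower number from compound 2 to compound 4 (0.33 log units; beyond the scatter), the first measured information about this part of the molecule, as all the earlier steps concerned the halogen. With the bromo group kept, this position accepts a group with a second six-membered aromatic ring and no hydrogen-bond acceptor without losing growth inhibition, and the number moves modestly in the stronger direction, a much smaller shift than a 360-fold lower number from compound 1 to compound 2 (2.55 log units; beyond the scatter). No measurement shown here accounts for this shift.

The swap changes two things at once, adding a second ring and removing the methoxy oxygen, so the compounds shown cannot tell which of the two matters; a plain phenyl group at this position would separate them. From the compounds shown here alone, it also remains open whether the same step holds with chloro in place of bromo, and how an amine or a carboxylic acid on the aromatic ring at this position would behave.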